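Methyl-placement isomers on the aryl ester of the flavone series

The source may report more compounds than this note shows. Statements on the series, on what has been measured and on what is new or still open speak of the compounds shown alone.

Measured so far in an ADME assay on cells (T-cell, Mus musculus, strain BALB/c) for cytotoxicity, read by MTT assay, with a stated time of 48 h; a lower number here means that less compound is tolerated, a higher number that more compound is tolerated:
compound 1 `COC(=O)c1cccc(C)c1OC(=O)COc1cc(O)c2c(=O)cc(-c3ccccc3)oc2c1` gives 299000 nM
compound 2 `COC(=O)c1c(C)cccc1OC(=O)COc1cc(O)c2c(=O)cc(-c3ccccc3)oc2c1` gives 298000 nM

Compound 2 stands lowest of the two numbers in this assay, with compound 1 nearest at a step that is a 1.0-fold lower number from compound 1 to compound 2 (0.00 log units; within the scatter). Compound 3 `COC(=O)c1cc(C)ccc1OC(=O)COc1cc(O)c2c(=O)cc(-c3ccccc3)oc2c1` is not yet measured; it differs from compound 2 by a group of 11 heavy atoms (9 carbon, 2 oxygen; one six-membered aromatic ring of carbon only) in place of a group of 11 heavy atoms (9 carbon, 2 oxygen; one six-membered aromatic ring of carbon only), on an oxygen next to a carbonyl group. Among the compounds with values here, the one step that bears on this change, a 1.0-fold lower number from compound 1 to compound 2 (0.00 log units; within the scatter), is within the scatter, so no step beyond the scatter is expected in this assay. The expected step from compound 2 to compound 3 is a 1.0-fold higher number from compound 2 to compound 3 (0.00 log units; within the scatter). For compound 3 the estimate is 300000 nM, with a range of 150000 nM to 600000 nM.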

Compound 3, half-maximal cytotoxic concentration: 306000 nM
Estimate against measurement, compound 3: 1.0-fold (0.01 log units) below; the range from low to high includes it.
By their numbers in this assay, from the lowest: compounds 2, 1 and 3 (each within the scatter of the next).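

In this assay, a third placement of the methyl on the aryl ester adds a 1.0-fold higher number from compound 2 to compound 3 (0.01 log units; within the scatter) and a 1.0-fold higher number from compound 1 to compound 3 (0.01 log units; within the scatter), so all three isomers now lie within the scatter of one another. Across these placements, moving the methyl around this ring gives no readable change in the tolerated concentration. Nothing at hand explains this flat result. Still open, as far as these compounds go, is whether an amine, a carboxylic acid or a longer chain on this ring would move the number. Also open, from the compounds shown here alone, is whether an amide in place of the ester link would do so.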